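This account rests on a few compounds, and the source may have more. Where it says the series, first, only, none or still open, it means among the compounds named here.

Compound 1 `COc1cc(OC)c(C(=O)c2cccc(Cl)c2)c(O)c1CN1CCCCC1`: 83% in a functional assay on THP-1 cells (Homo sapiens) for inhibition, read by ELISA, with stated times of 30 min and 24 h, tested at 10 uM; a lower number here means a weaker effect, a higher number a stronger effect of the compound at the concentration tested
Compound 2 `COc1cc(OC)c(C(=O)c2cccc(F)c2)c(O)c1CN1CCCCC1`: 87%

In this assay compound 2 stands highest of the two numbers, with compound 1 nearest, though the step of a number 4 percentage points higher from compound 1 to compound 2 (within the scatter) lies within the scatter. Compound 3 `COc1cc(OC)c(C(=O)c2cccc(F)c2)c(O)c1CN1CCCC1` differs from compound 2 by pyrrolidin-1-yl in place of piperidin-1-yl on a saturated chain carbon bound to an aromatic carbon. Going by the values given here, no measured step touches the ring on the saturated chain carbon; the only measured step, a number 4 percentage points higher from compound 1 to compound 2 (within the scatter), concerns the halogen and bears on this change only by showing that the shared core holds its high activity under small edits. The step of a number 5 percentage points lower from compound 2 to compound 3 (within the scatter) is therefore expected to fall within the scatter. Compound 3 is estimated at 82%, between 65% and 94%.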

Compound 3, a percentage reported as activity, at one concentration (the size of the read-out at that concentration, not a potency): 93%
Beside the measured number, compound 3's estimate is 11 percentage points below it; measured number inside the range.
By their numbers in this assay, from the lowest: compounds 1, 2 and 3 (each within the scatter of the next).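

Placing pyrrolidin-1-yl in place of piperidin-1-yl on a saturated chain carbon bound to an aromatic carbon gives, in this assay, a number 6 percentage points higher from compound 2 to compound 3 (within the scatter) and is the first measured edit at this position. The position therefore accepts a five-membered ring as well as a six-membered one, with no difference beyond the scatter. From the compounds shown here alone, whether morpholin-4-yl, an open-chain diethylamino group or a carboxylic acid at this place would keep the read-out as high remains open. No measurement shown explains this result.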